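Methylthiazole for furan on the imidazoline ether series

The compounds below may be only part of what the source reports. "The series", "measured", "known", "first", "only" and "open" are said of these compounds alone.

Within the data shown here, compound 2 `c1coc(-c2ccccc2OCC2=NCCN2)c1` is the one member of this set with a number rather than a limit: in a functional assay for activation of Alpha-1B adrenergic receptor (Homo sapiens), read by calcium flux (on this read-out higher numbers stand for an effect only at larger amounts of compound and lower numbers for an effect already at smaller amounts), compound 2 gives 10 nM. Compound 1 `c1ccc(-c2ccncn2)c(OCC2=NCCN2)c1` returns only a limit of the assay, < 100000 nM, in this assay. Compound 3 `Cc1ccoc1-c1ccccc1OCC1=NCCN1` likewise returns only a limit, < 100000 nM, in this assay. The three measured steps therefore cannot be sized: a step that the limit leaves unreadable from compound 1 to compound 2, a step that the two limits leave unreadable from compound 1 to compound 3 and a step that the limit leaves unreadable from compound 2 to compound 3. Both limits sit at the same point (the limit of < 100000 nM in this assay, at which 2 of the 3 values shown sit), so the steps away from compound 2 are known only in direction, not in extent.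

Compound 4 `Cc1csc(-c2ccccc2OCC2=NCCN2)n1` differs from compound 2 by 4-methyl-1,3-thiazol-2-yl in place of furan-2-yl on an aromatic carbon. Two of the measured steps touch this change: the methyl in place of hydrogen on the five-membered ring in the step from compound 2 to compound 3, and the replacement of one heteroaryl by another in the step from compound 1 to compound 2. Neither gives a readable size, but both end at the limit when moving away from compound 2, so a loss is expected in this assay, of unknown size, as a 300-fold higher number from compound 2 to compound 4 (2.48 log units; beyond the scatter). Compound 4 is accordingly estimated at 3000 nM, within 200 nM to 100000 nM.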

Compound 4, half-maximal effective concentration: < 100000 nM
Compound 4 was reported as a limit; the forecaster's own chance of this, stated with the estimate: 40%; the middle value does not contradict the limit.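

Compound 4 gives < 100000 nM in this assay as a limit of the assay, so no new step can be read between compound 4 and compound 1, compound 2 or compound 3. The compounds shown leave open how far compound 1, compound 3 and compound 4 each lie from compound 2, and whether they differ from one another.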